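Aryloxy replacement on the core of compound 1

The compounds below may be only part of what the source reports. "The series", "measured", "known", "first", "only" and "open" are said of these compounds alone.

Compound 1 `Cc1ccc(NC(=O)c2cccc(C(F)(F)F)c2)cc1N1Cc2cnc(O[C@H]3CCN(C(=O)OC(C)(C)C)C3)nc2N(C)C1=O` carries the only numerical result in the series: in an ADME assay on BaF3 cells (Mus musculus) for antiproliferative activity, read by CellTiter-Glo and CCK-8 assay, with a stated time of 72 h (on this read-out lower numbers stand for stronger inhibition of growth and higher numbers for weaker inhibition of growth), compound 1 gives 8380 nM, the single number shown. Compound 2 `Cc1cc(C)cc(C(=O)Nc2ccc(C)c(N3Cc4cnc(Nc5ccc(C)c(N)c5)nc4N(C)C3=O)c2)c1` reaches only the limit of this assay, giving > 10000 nM, which is the limit of > 10000 nM in this assay, at which 1 of the 2 values shown sits. Compound 3 `Cc1ccc(Oc2ncc3c(n2)N(C)C(=O)N(c2cc(NC(=O)c4cccc(C(F)(F)F)c4)ccc2C)C3)cc1N` differs from compound 1 by 3-amino-4-methylphenyl in place of 1-(tert-butoxycarbonyl)pyrrolidin-3-yl on an oxygen on an aromatic ring. Among the measured compounds shown here, no measured step of this kind exists, so no direction beyond the scatter is expected. Compound 3 is expected near 8000 nM (range 2000 nM to 30000 nM), an estimated step of a 1.0-fold lower number from compound 1 to compound 3 (0.02 log units; within the scatter).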

Compound 3, concentration for 50% growth inhibition: > 10000 nM
Compound 3 gave a limit, no number; the forecaster's own chance of this, stated with the estimate: 40%; at least 1.2-fold (0.09 log units) between middle value and limit.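

In this assay compound 3 gives > 10000 nM, which is a limit of the assay and not a number. With 3-amino-4-methylphenyl in place of 1-(tert-butoxycarbonyl)pyrrolidin-3-yl on this oxygen, the step is an at least 1.1-fold higher number from compound 1 to compound 3 (0.07 log units; that floor lies within the scatter), so the aromatic group brings no stronger inhibition of growth, and the true size of the step cannot be read. Most of the series now sits at the ceiling: the limit of > 10000 nM in this assay, at which 2 of the 3 values shown sit.

Still open, as far as these compounds go, is whether a piperidin-4-yl amine or a plain methyl on this oxygen would give a number well below that ceiling.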